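Phenyl in place of pyridin-2-yl on the shared core

The source may hold more compounds than are shown below. What is called first, only, known or untested is meant among the compounds shown, and "the series" means these compounds.

Measured compounds in an assay on isolated protein for inhibition of Fatty-acid amide hydrolase 1 (Rattus norvegicus); a lower number here means a stronger inhibitor, a higher number a weaker inhibitor:
compound 1 `O=C(CCCCCCc1ccccc1)c1nc(Cl)co1` gives 4 nM
compound 2 `O=Cc1coc(C(=O)CCCCCCc2ccccc2)n1` gives 55 nM
compound 3 `O=C(CCCCCCc1ccccc1)c1nc(-c2ccccn2)co1` gives 1.9 nM

Compound 3 stands at the lowest number of the three in this assay. Its nearest neighbour is compound 1, reached by a 2.1-fold lower number from compound 1 to compound 3 (0.32 log units; beyond the scatter), a modest step; the furthest is compound 2, with a 29-fold lower number from compound 2 to compound 3 (1.46 log units; beyond the scatter), a large step. The remaining step, a 14-fold higher number from compound 1 to compound 2 (1.14 log units; beyond the scatter), shows that what sits on this carbon of the shared core can shift the number a great deal.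

Compound 4 `O=C(CCCCCCc1ccccc1)c1nc(-c2ccccc2)co1` has not yet been measured. The change from compound 3 is phenyl in place of pyridin-2-yl on an aromatic carbon. Among the compounds with values here, no measured step exchanges pyridin-2-yl for phenyl, so nothing here speaks directly to this change. The two steps that arrive at pyridin-2-yl, from chloro and from formyl, both lower the number, and the group that enters keeps the six-membered aromatic ring while giving up the one hydrogen-bond acceptor. A small to modest step toward a higher number is therefore expected, a 3.2-fold higher number from compound 3 to compound 4 (0.50 log units; beyond the scatter), though a result within the scatter would not surprise.

Compound 4 is expected to give 6 nM in this assay, with a range of 2 nM to 20 nM.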

Compound 4, inhibition constant: 65 nM
Compound 4: the middle estimate sits 11-fold (1.03 log units) below what was measured; the measured number lies above the stated range.
By their numbers in this assay, from the lowest: compound 3; then compound 1; then compounds 2 and 4 (each within the scatter of the next).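

With the six-membered aromatic ring kept and only its ring nitrogen replaced by carbon, this assay records a 34-fold higher number from compound 3 to compound 4 (1.53 log units; beyond the scatter) as the result of phenyl in place of pyridin-2-yl on this aromatic carbon, so the low number of compound 3 does not come with the six-membered aromatic ring alone. Measured against the two smaller groups, phenyl gives a 16-fold higher number from compound 1 to compound 4 (1.21 log units; beyond the scatter) when it replaces chloro, while replacing formyl gives a 1.2-fold higher number from compound 2 to compound 4 (0.07 log units; within the scatter) and so leaves compounds 2 and 4 level in this assay. Before this result, the only aromatic ring at this carbon was pyridin-2-yl, and it gave the lowest number; compound 4 shows that in this short series an aromatic ring here can instead sit as high as formyl, and that one ring atom separates the two outcomes.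

Still open, from the compounds shown here alone, is whether pyridin-3-yl or pyridin-4-yl, or a carboxylic acid or an amine carried on the phenyl of compound 4, would return the number toward that of compound 3. Nothing among the data shown accounts for the size of the step between phenyl and pyridin-2-yl.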